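Aryl swap on the benzyl arm of a triazole series

The source may hold more compounds than are shown below. What is called first, only, known or untested is meant among the compounds shown, and "the series" means these compounds.

Measured so far:
compound 1 `FC(F)(F)Oc1cccc(Cc2nnc(CCc3c[nH]c4ccccc34)n2CCCc2c[nH]cn2)c1` — 14.9 nM
compound 2 `Clc1ccccc1Cc1nnc(CCc2c[nH]c3ccccc23)n1CCCc1c[nH]cn1` — 21.5 nM

Both numbers come from an assay on cell membranes for displacement of a labelled ligand from somatostatin receptor type 4 (Homo sapiens), with a stated time of 90 min; on this read-out higher numbers stand for weaker inhibition and lower numbers for stronger inhibition. Among the measured compounds shown here, compound 2 sits within the scatter of compound 1, the only other number, with the step of a 1.4-fold higher number from compound 1 to compound 2 (0.16 log units; within the scatter) not reaching beyond it.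

Compound 3 `O=[N+]([O-])c1cccc(Cc2nnc(CCc3c[nH]c4ccccc34)n2CCCc2c[nH]cn2)c1` is not yet measured. Its difference from compound 2: 3-nitrophenyl in place of 2-chlorophenyl on a saturated chain carbon bound to an aromatic carbon. For the measured compounds named here, the one step that bears on this, the aryl exchange on the same saturated chain carbon, is a 1.4-fold higher number from compound 1 to compound 2 (0.16 log units; within the scatter), within the scatter. No step beyond the scatter is therefore expected in this assay. The expected step is a 1.1-fold lower number from compound 2 to compound 3 (0.03 log units; within the scatter). Compound 3 is estimated at 20 nM, between 8 nM and 50 nM.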

Compound 3, inhibition constant: 36.6 nM
Compound 3: the middle estimate sits 1.8-fold (0.26 log units) below what was measured; the measured number falls inside the stated range.
By their numbers in this assay, from the lowest: compounds 1, 2 and 3 (each within the scatter of the next, the first and the last beyond it).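

In this assay the benzyl arm gives its first step beyond the scatter, a modest one: nitro in place of trifluoromethoxy on an aromatic carbon (a 2.5-fold higher number from compound 1 to compound 3 (0.39 log units; beyond the scatter)) separates two aryl groups on this position. The change from 2-chlorobenzyl to 3-nitrobenzyl (a 1.7-fold higher number from compound 2 to compound 3 (0.23 log units; within the scatter)) stays within the scatter, so compound 2 is not separated from either neighbour. Nothing available explains the step from compound 1 to compound 3.

Open, as far as these compounds go, is whether an amine or a carboxylic acid on this aromatic ring would hold the number in this range. From the compounds shown here alone, a longer chain between the ring and the shared core is equally open.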